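The source may hold more compounds than are shown below. What is called first, only, known or untested is meant among the compounds shown, and "the series" means these compounds.

Measured compounds in a functional assay on A-431 cells (Homo sapiens) for antiproliferative activity, read by sulforhodamine B assay, with a stated time of 72 h; a lower number here means a stronger inhibitor, a higher number a weaker inhibitor:

- compound 1, `CN(C)CCNC(=O)Nc1cc2c(Nc3ccc(F)c(Cl)c3)ncnc2cc1O[C@H]1CCOC1`, 806 nM
- compound 2, `CCN(CC)CCN(C)C(=O)Nc1cc2c(Nc3ccc(F)c(Cl)c3)ncnc2cc1O[C@H]1CCOC1`, 481 nM
- compound 3, `O=C(Nc1cc2c(Nc3ccc(F)c(Cl)c3)ncnc2cc1O[C@H]1CCOC1)N1CCC(F)CC1`, 3040 nM

Within the data shown here, compound 3 stands at the highest number of the series so far. Both steps into it point the same way: a 3.8-fold higher number from compound 1 to compound 3 (0.58 log units; beyond the scatter) and a 6.3-fold higher number from compound 2 to compound 3 (0.80 log units; beyond the scatter), each a modest rise and each beyond the scatter. The remaining step, a 1.7-fold lower number from compound 1 to compound 2 (0.22 log units; within the scatter), falls within the scatter.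

Compound 4 is `O=C(Nc1cc2c(Nc3ccc(F)c(Cl)c3)ncnc2cc1O[C@H]1CCOC1)N1CCC(F)(F)CC1`. It differs from compound 3 by fluoro in place of hydrogen on a saturated ring carbon; the group carrying the change is thus 4-fluoropiperidin-1-yl becoming 4,4-difluoropiperidin-1-yl on the carbonyl. Among the measured compounds shown here, none of the measured steps touches this ring carbon; all three exchange the whole amine on the carbonyl carbon, so they show only where the piperidine-bearing compound sits, not what a second fluoro does there. For the measured compounds named here, with no measured step bearing on the change, the expectation is a step of no size beyond the scatter in this assay, a 1.1-fold higher number from compound 3 to compound 4 (0.05 log units; within the scatter), with the direction open.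

Compound 4 is therefore estimated at 3400 nM in this assay, within a range of 1400 nM to 8500 nM.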

Compound 4, half-maximal inhibitory concentration: 1860 nM
Estimate against measurement, compound 4: 1.8-fold (0.26 log units) above, and the stated range covers the measured number.
By their numbers in this assay, from the lowest: compounds 2 and 1 (each within the scatter of the next); then compounds 4 and 3 (each within the scatter of the next).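

Notes on the ring carbon of the piperidine: in this assay, the step that adds a second fluoro at this carbon, three ring bonds from the ring nitrogen, is a 1.6-fold lower number from compound 3 to compound 4 (0.21 log units; within the scatter) and so gives the first direct reading at this position, where 4-fluoropiperidin-1-yl and 4,4-difluoropiperidin-1-yl cannot be told apart. The distance from the two amine chains on the carbonyl persists with the second fluoro in place, at a 3.9-fold higher number from compound 2 to compound 4 (0.59 log units; beyond the scatter) and at a 2.3-fold higher number from compound 1 to compound 4 (0.36 log units; beyond the scatter) in the same assay, so among these four compounds the steps beyond the scatter are those that exchange the whole amine on the carbonyl, while the one fluoro step stays within it. No measured evidence on the cause of any of these steps is available.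

Still open, on these data alone, is how the plain piperidin-1-yl group, with hydrogen in place of both fluoro atoms, would stand against compound 3 and compound 4. Also open, as far as these compounds go, is whether a hydroxyl, a methyl or a dimethylamino group on this ring carbon would give a step beyond the scatter, which would show whether the position responds to any change at all.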